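Moving the hydroxyl on the cyclohexyl of compound 2

This account rests on a few compounds, and the source may have more. Where it says the series, first, only, none or still open, it means among the compounds named here.

Measured compounds:
compound 1 `O=C(NCCCOc1ccc2nc(O)ccc2c1)N(C1CCCC1)[C@H]1CCCC[C@@H]1O` gives 20%
compound 2 `O=C(NCCCOc1ccc2nc(O)ccc2c1)N(C1CC1)[C@H]1CC[C@H](O)CC1` gives 7%

In a functional assay on the whole organism for inhibition, with Rattus norvegicus as the target, at a dose of 30 mg/kg by the oral route (on this read-out higher numbers stand for more inhibition at the one dose given (going by the name of the read-out) and lower numbers for less inhibition), compound 2 stands lowest of the two measured compounds, and its gap to compound 1 lies beyond the usual scatter. Compound 3 `O=C(NCCCOc1ccc2nc(O)ccc2c1)N(C1CC1)[C@H]1CCCC[C@@H]1O` keeps the cyclopropyl of compound 2 and carries 2-hydroxycyclohexyl in place of 4-hydroxycyclohexyl on an amide-type nitrogen. Within the data shown here, no step between measured compounds isolates this change, so the direction is uncertain; a modest rise is expected because compound 1 with the same 2-hydroxycyclohexyl gives 20%. Compound 3 is expected to show a step of a number 5 percentage points higher from compound 2 to compound 3 (within the scatter). Compound 3 is therefore estimated at 12%, within 3% to 25%.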

Compound 3, a percentage reported as inhibition, in the whole organism at one dose (the size of the read-out at that dose, not a potency): 13%
Beside the measured number, compound 3's estimate is 1 percentage points below it; the measured number falls inside the stated range.
By their numbers in this assay, from the lowest: compounds 2, 3 and 1 (each within the scatter of the next, the first and the last beyond it).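

In this assay, 2-hydroxycyclohexyl in place of 4-hydroxycyclohexyl on the amide-type nitrogen gives a number 6 percentage points higher from compound 2 to compound 3 (within the scatter), so the two placements of the hydroxyl cannot be told apart here. With 2-hydroxycyclohexyl kept, cyclopropyl in place of cyclopentyl gives a number 7 percentage points lower from compound 1 to compound 3 (within the scatter), so this change cannot be resolved either, although compound 1 and compound 2 lie beyond the scatter of each other.

From the compounds shown here alone, whether an amine or a carboxylic acid in place of the hydroxyl would shift the read-out remains open. Nothing available accounts for either step.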